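Ring attachment and nitrogen methylation in an adrenergic series

The source may report more compounds than this note shows. Statements on the series, on what has been measured and on what is new or still open speak of the compounds shown alone.

Compound 3 `c1ccc(-c2cn[nH]c2)c(NCC2=NCCN2)c1` gives the largest maximal response of the three measured compounds in a functional assay with Alpha-1A adrenergic receptor (Homo sapiens) as the target, read by calcium flux (a lower number here means a smaller maximal response, a higher number a larger maximal response), with 112%. Its nearest neighbour in the numbers is compound 1 `Cn1cc(-c2ccccc2NCC2=NCCN2)cn1`, which gives 39% in this assay; compound 2 `CC(C)n1nccc1-c1ccccc1NCC1=NCCN1` lies furthest away, giving 0% in this assay. Within the data shown here, the only measured step between compounds that differ in one place is a number 73 percentage points higher from compound 1 to compound 3 (beyond the scatter), so removing the methyl from the ring nitrogen raises the response considerably.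

Compound 4 `Cn1nccc1-c1ccccc1NCC1=NCCN1` differs from compound 3 by 1-methyl-1H-pyrazol-5-yl in place of 1H-pyrazol-4-yl on an aromatic carbon. The change brings back a methyl on an aromatic nitrogen, the feature whose removal gave a number 73 percentage points higher from compound 1 to compound 3 (beyond the scatter), and it makes compound 4 resemble compound 2, which carries an isopropyl group rather than a methyl and gives 0% in this assay. Among the measured compounds shown here, no measured step covers the change of ring attachment alone, so for that part only the two values of compound 1 and compound 2 can be consulted. The expectation is therefore a large drop in this assay, estimated at a number 92 percentage points lower from compound 3 to compound 4 (beyond the scatter). Compound 4 is expected to give 20% in this assay, within a range of 0% to 55%.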

Compound 4, largest response reached (reported as maximal response), in percent of the reference or control that the assay uses: 108%
The estimate for compound 4 lay 88 percentage points below the measured number; measured number outside the range, above it.
By their numbers in this assay, from the lowest: compound 2; then compound 1; then compounds 4 and 3 (each within the scatter of the next).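

In this assay, the step for 1-methyl-1H-pyrazol-5-yl in place of 1H-pyrazol-4-yl on an aromatic carbon is a number 4 percentage points lower from compound 3 to compound 4 (within the scatter), so a methyl on an aromatic nitrogen does not by itself go with a low maximal response in this series. With the methyl kept and only the ring attachment altered, the step is a number 69 percentage points higher from compound 1 to compound 4 (beyond the scatter), which shows that the effect of the methyl seen earlier holds for the 1-methyl-1H-pyrazol-4-yl compound and not for compound 4. With the attachment kept, the group on the ring nitrogen still matters, as methyl in place of isopropyl gives a number 108 percentage points higher from compound 2 to compound 4 (beyond the scatter) for this 1-methyl-1H-pyrazol-5-yl type of substituent.

Open, from the compounds shown here alone, is where the sharp loss sets in on the ring nitrogen of this attachment, since an ethyl or a cyclopropyl group could stay with compound 4 or fall with compound 2. Also open, going by these compounds, is whether the parent 1H-pyrazol-5-yl group, without any group on nitrogen, stays with compound 3 and compound 4.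

No measurement at hand accounts for these differences.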